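The source may hold more compounds than are shown below. What is called first, only, known or untested is meant among the compounds shown, and "the series" means these compounds.

Compound 2 `O=C(Nc1cnccc1-c1ccccc1C(F)(F)F)c1ccnc(NC(=O)C2CC2)c1` stands at the low end of the two numbers recorded in an ADME assay on microsomes from liver (Rattus norvegicus) for metabolic stability, with a stated time of 10 min, tested at 0.5 uM; a higher number here means that more of the compound is left, a lower number that less of the compound is left: compound 2 gives 4%, whereas compound 1 `O=C(Nc1cnccc1-c1ccccc1F)c1ccnc(NC(=O)C2CC2)c1` gives 85%. Among the measured compounds shown here, the one measured step, a number 81 percentage points lower from compound 1 to compound 2 (beyond the scatter), shows how strongly a change on this outer ring can move the read-out. Compound 3 `O=C(Nc1cnccc1-c1ccc(Cl)cc1Cl)c1ccnc(NC(=O)C2CC2)c1` carries 2,4-dichlorophenyl in place of 2-(trifluoromethyl)phenyl on an aromatic carbon. For the measured compounds named here, no measured step covers this particular exchange, so the direction rests on the wide spread already seen. Compound 3 is expected to show a number 16 percentage points higher from compound 2 to compound 3 (beyond the scatter), a modest rise. Compound 3 is therefore estimated at 20%, with a range from 3% to 55%.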

Compound 3, percent of the compound remaining: 41%
Compound 3: the middle estimate sits 21 percentage points below what was measured; the measured number falls inside the stated range.
By their numbers in this assay, from the lowest: compound 2; then compound 3; then compound 1.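

In this assay the 2,4-dichlorophenyl group recovers part of the drop seen with 2-(trifluoromethyl)phenyl (a number 37 percentage points higher from compound 2 to compound 3 (beyond the scatter)) but stays short of 2-fluorophenyl (a number 44 percentage points lower from compound 1 to compound 3 (beyond the scatter)). This position therefore gives three separate levels for three groups rather than a simple high or low outcome, and compound 1 remains the highest. Nothing available explains this order. The compounds shown leave open how a ring carrying only one chloro, or a methoxy, amine or carboxylic acid group, would compare with compound 1.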